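A Group Exchanged on a Carbonyl Carbon

The source may report more compounds than this note shows. Statements on the series, on what has been measured and on what is new or still open speak of the compounds shown alone.

Among the compounds with values here, in an ADME assay on microsomes from liver (Mus musculus) for metabolic stability, read by LC-MS, with a stated time of 30 min, tested at 1 uM (on this read-out higher numbers stand for a more stable compound and lower numbers for a less stable compound), compound 1 `O=C(NCc1ccc(S(=O)(=O)c2ccccc2)cc1)c1nc2ccncc2s1` gives 26%, the lower of the two numbers so far. Compound 2 `O=C(NCc1ccc(S(=O)(=O)c2ccccc2C(F)(F)F)cc1)c1cc2cnccc2[nH]1` stands higher at 41%, a gap beyond the usual scatter. Compound 3 `O=C(NCc1ccc(S(=O)(=O)c2ccccc2)cc1)c1ccc2nncn2c1` has not yet been measured. It differs from compound 1 in one place, on a carbonyl carbon: a group of 9 heavy atoms (6 carbon, 3 nitrogen; one five-membered aromatic ring with 3 hetero atoms, one six-membered aromatic ring with 1 hetero atom) in place of a group of 9 heavy atoms (6 carbon, 2 nitrogen, 1 sulfur; one five-membered aromatic ring with 2 hetero atoms, one six-membered aromatic ring with 1 hetero atom), on a carbonyl carbon. Within the data shown here, no measured pair shows what such an exchange does. The expected step of a number 6 percentage points higher from compound 1 to compound 3 (within the scatter) is a small rise in this assay, within the scatter. For compound 3 the estimated value is 32%, with an expected range from 12% to 55%.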

Compound 3, percent of the compound remaining: 47%
For compound 3 the middle estimate is 15 percentage points below the measured one; low and high end bracket the measured number.
By their numbers in this assay, from the lowest: compound 1; then compounds 2 and 3 (each within the scatter of the next).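

Within the data shown here, at this carbonyl carbon, the exchange gives the first measured step in this assay: a number 21 percentage points higher from compound 1 to compound 3 (beyond the scatter). The number therefore responds to this group even though the two groups match in heavy-atom count, ring sizes, hydrogen-bond donors and acceptors, and net charge. Nothing measured here explains the change.

Still open, from the compounds shown here alone, is how a group carrying an amine or a carboxylic acid would behave on this carbonyl carbon. Going by these compounds, it is also open whether the same exchange would give a similar step with the rest of the molecule altered.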